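Thiazolidinedione ylidene replaces methylhydantoin on the EP3 antagonist series

The source may hold more compounds than are shown below. What is called first, only, known or untested is meant among the compounds shown, and "the series" means these compounds.

The measured compounds:
compound 1, `CC(C)[C@H](C[C@H]1OC(=O)NC1=O)c1ccc(-c2ccc3cccc(F)c3c2)[nH]c1=O`, 15 nM
compound 2, `Cc1cc(C(/C=C2\OC(=O)NC2=O)C(C)C)c(=O)[nH]c1-c1ccc2cccc(F)c2c1`, 92 nM
compound 3, `CC(C)C(c1ccc(-c2ccc3cccc(F)c3c2)[nH]c1=O)C1C(=O)NC(=O)N1C`, 320 nM

In a functional assay on CHO cells for antagonist activity at prostaglandin E2 receptor EP3 subtype (Homo sapiens), read by cAMP accumulation, with a stated time of 30 min (on this read-out higher numbers stand for weaker inhibition and lower numbers for stronger inhibition), compound 3 gives the highest number of the three, so it is the weakest inhibitor shown. Compound 2 lies nearest to it, and compound 1 lies furthest, each separation beyond the usual scatter.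

Compound 4, `CC(C)C(/C=C1\SC(=O)NC1=O)c1ccc(-c2ccc3cccc(F)c3c2)[nH]c1=O`, has not yet been measured. It differs from compound 3 by a group of 8 heavy atoms (4 carbon, 1 nitrogen, 2 oxygen, 1 sulfur; one five-membered non-aromatic ring with 2 hetero atoms) in place of a group of 8 heavy atoms (4 carbon, 2 nitrogen, 2 oxygen; one five-membered non-aromatic ring with 2 hetero atoms), on a saturated chain carbon bound to an aromatic carbon and a saturated chain carbon. The entering group, with its 3 double bonds outside aromatic rings and 1 sulfur, resembles the unsaturated ring of compound 2 more than the saturated one of compound 3.

Among the compounds with values here, no measured pair tracks this exact change. Compound 4 is expected to move toward the stronger end, since compound 2 gives 92 nM and compound 1 gives 15 nM; the step of a 5.3-fold lower number from compound 3 to compound 4 (0.73 log units; beyond the scatter) is estimated to be downward and beyond the scatter. For compound 4 the estimate in this assay is 60 nM, with a range from 20 nM to 200 nM.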

Compound 4, half-maximal inhibitory concentration: 27 nM
Compound 4: middle estimate off by 2.2-fold (0.35 log units), on the high side; the range from low to high includes it.
By their numbers in this assay, from the lowest: compounds 1 and 4 (each within the scatter of the next); then compound 2; then compound 3.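

On the saturated chain carbon bound to an aromatic carbon and a saturated chain carbon, replacing the 3-methyl-2,5-dioxoimidazolidin-4-yl group with the sulfur-containing unsaturated ring gives a large change in this assay, a 12-fold lower number from compound 3 to compound 4 (1.07 log units; beyond the scatter), so this position is highly sensitive to the identity of the ring it carries. With this ring, compound 4 gives 27 nM, within the scatter of compound 1 at 15 nM, so the sulfur-containing ring reaches the low end of the numbers shown here. Nothing shown here explains why the change has this effect.

Because the entering group differs in both its sulfur and its double bonds outside aromatic rings, the compounds shown do not separate the contribution of each. From the compounds shown here alone, how a carboxylic acid or a tetrazole would read at this position also remains open.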